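Aryl amide variation on a shared core

The source may hold more compounds than are shown below. What is called first, only, known or untested is meant among the compounds shown, and "the series" means these compounds.

Compound 1 `CCN1CCN(c2cc(C)c3cc(NC(=O)c4ccc(Cl)cc4)ccc3n2)CC1` is the reference point for this comparison. In a functional assay on SK-BR-3 cells (Homo sapiens) for antiproliferative activity, read by MTT assay, with a stated time of 72 h (a lower number here means a stronger inhibitor, a higher number a weaker inhibitor), compound 1 gives 3020 nM, the second highest of the three numbers in hand. Compound 2 `CCN1CCN(c2cc(C)c3cc(NC(=O)c4cc(Cl)cc(Cl)c4)ccc3n2)CC1` gives 2660 nM in this assay, and the step of a 1.1-fold lower number from compound 1 to compound 2 (0.06 log units; within the scatter) lies within the scatter. Compound 3 `CCN1CCN(c2cc(C)c3cc(NC(=O)c4cccnc4)ccc3n2)CC1` gives 10600 nM in this assay; the steps of a 3.5-fold higher number from compound 1 to compound 3 (0.55 log units; beyond the scatter) and a 4.0-fold higher number from compound 2 to compound 3 (0.60 log units; beyond the scatter) are both beyond the scatter, so the two chlorinated amides stand apart from compound 3 but not from each other.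

Compound 4 `CCN1CCN(c2cc(C)c3cc(NC(=O)c4ccc(Cl)c(Cl)c4)ccc3n2)CC1` has not been measured. Against compound 1 the difference is chloro in place of hydrogen on an aromatic carbon. Going by the values given here, the step that bears on this is a 1.1-fold lower number from compound 1 to compound 2 (0.06 log units; within the scatter), where a further chlorine on the aryl amide left the number unchanged within the scatter; no measured pair shows an added chloro moving the number beyond it. Compound 3 shows only that a pyridin-3-yl amide gives a weaker inhibitor, not how a chlorinated phenyl responds to a second chloro. The expected step of a 1.1-fold lower number from compound 1 to compound 4 (0.05 log units; within the scatter) is therefore small, within the scatter, with no direction claimed. Compound 4 is estimated at 2700 nM in this assay, within the range 1300 nM to 5600 nM.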

Compound 4, half-maximal inhibitory concentration: 2160 nM
For compound 4 the middle estimate is 1.3-fold (0.10 log units) above the measured one; low and high end bracket the measured number.
By their numbers in this assay, from the lowest: compounds 4, 2 and 1 (each within the scatter of the next); then compound 3.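

Chloro in place of hydrogen on this aromatic carbon, ortho to a chloro group, gives the first direct reading of a second chloro added to the 4-chlorophenyl amide: in this assay the step of a 1.4-fold lower number from compound 1 to compound 4 (0.15 log units; within the scatter) lies within the scatter, and the change of dichloro pattern, a 1.2-fold lower number from compound 2 to compound 4 (0.09 log units; within the scatter), does so too, so neither the added chloro nor its place separates these amides. Compound 3 now stands apart from all three chlorinated amides, with a 4.9-fold lower number from compound 3 to compound 4 (0.69 log units; beyond the scatter) beyond the scatter, in line with its steps to compound 1 and compound 2. No measurement in hand accounts for any of these steps.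

The compounds shown leave open whether a group other than chloro on this aromatic carbon, such as a methoxy, a nitrile or an amine, would move the number beyond the scatter, and whether an unsubstituted phenyl amide would sit with the chlorinated amides or with compound 3. They also leave open how the number responds to changes away from the aryl amide, for instance a longer chain on the shared core.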